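The compounds below may be only part of what the source reports. "The series", "measured", "known", "first", "only" and "open" are said of these compounds alone.

Series notes. Compound 1 `CN(c1cc2ncc(=O)[nH]c2cc1NC(=N)NCc1cccc(C(F)(F)F)c1)C1CCCCC1`, compound 2 `CN(c1cc2ncc(=O)[nH]c2cc1Nc1nc(-c2ccccc2)cs1)C1CCCCC1` and compound 3 `CN(c1cc2ncc(=O)[nH]c2cc1Nc1nc(-c2ccc(C#N)cc2)cs1)C1CCCCC1` share one core. For the measured compounds named here, in an ADME assay on Huh-7 cells (Homo sapiens) for cytotoxicity (a lower number here means a stronger inhibitor, a higher number a weaker inhibitor), compound 1 gives 54000 nM, compound 2 gives 62500 nM and compound 3 gives 18100 nM, so compound 3 stands at the lowest number of the three, and the one step comparable in one place, a 3.5-fold lower number from compound 2 to compound 3 (0.54 log units; beyond the scatter), is the only measured step on this side chain. Compound 4 `CN(c1cc2ncc(=O)[nH]c2cc1Nc1nc(-c2cccnc2)cs1)C1CCCCC1` differs from compound 3 by pyridin-3-yl in place of 4-cyanophenyl on an aromatic carbon. Going by the values given here, the cyanophenyl is lost here, so the pull that compound 3 gained through a 3.5-fold lower number from compound 2 to compound 3 (0.54 log units; beyond the scatter) may be given back in part; the new ring nitrogen has no measured precedent. Compound 4 is therefore expected near 35000 nM, range 12000 nM to 90000 nM, an expected step of a 1.9-fold higher number from compound 3 to compound 4 (0.29 log units; within the scatter) from compound 3 in this assay.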

Compound 4, half-maximal inhibitory concentration: 11500 nM
For compound 4 the middle estimate is 3.0-fold (0.48 log units) above the measured one; the whole stated range lies above it.
By their numbers in this assay, from the lowest: compounds 4 and 3 (each within the scatter of the next); then compounds 1 and 2 (each within the scatter of the next).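

At this position in this assay, a move away from phenyl beyond the scatter does not depend on the 4-cyanophenyl group or its nitrile: pyridin-3-yl gives a 5.4-fold lower number from compound 2 to compound 4 (0.74 log units; beyond the scatter). Exchanging one of these rings for the other gives a 1.6-fold lower number from compound 3 to compound 4 (0.20 log units; within the scatter), so the data do not separate pyridin-3-yl from 4-cyanophenyl here. Nothing available explains either step. Still open, on these data alone, is whether pyridin-4-yl or an amine or carboxylic acid on the phenyl ring would give a comparable step. As far as these compounds go, whether any such step carries over to compound 1, with its different side chain on the shared core, is also open.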